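From Compound 2 to Compound 3: One Added Group

A few compounds are considered here, and "the series" means these few. Any claim that something is new, unique, unknown or untested is made for them only; others in the source may bear on it.

In a physicochemical assay for lipophilicity (on this read-out lower numbers stand for lower lipophilicity and higher numbers for higher lipophilicity), two related compounds have been measured so far. Compound 1 `COc1cc(/C=C2\CCC/C(=C\c3ccccc3[N+](=O)[O-])C2=O)cc(OC)c1OC` gives 4.33, and compound 2 `O=C1/C(=C/c2ccccc2)CCC/C1=C\c1ccc([N+](=O)[O-])cc1` gives 4.93. Compound 2 therefore stands higher of the two, and the gap lies beyond the usual scatter of repeated measurements. These two compounds differ in more than one place, so their gap cannot be tied to any single change.

Compound 3 `CN(C)c1ccc(/C=C2\CCC/C(=C\c3ccc([N+](=O)[O-])cc3)C2=O)cc1` is still unmeasured. It keeps the core of compound 2 and differs from it in one place: dimethylamino in place of hydrogen on an aromatic carbon. In words, dimethylamino stands in place of hydrogen on an aromatic carbon, so a phenyl becomes a 4-(dimethylamino)phenyl. Going by the values given here, no measured pair shows this change on its own, so the expectation is only a rough one. A small rise in this assay is expected, one that may not exceed the scatter. The estimated step is a number 0.17 log units higher from compound 2 to compound 3 (within the scatter). For compound 3 the estimated value is 5.1, with an expected range from 4.6 to 5.6.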

Compound 3, partition coefficient: 5.03
Estimate against measurement, compound 3: 0.07 log units above; low and high end bracket the measured number.
By their numbers in this assay, from the lowest: compound 1; then compounds 2 and 3 (each within the scatter of the next).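

In this assay, going by these compounds alone, the swap of hydrogen for dimethylamino gives a number 0.10 log units higher from compound 2 to compound 3 (within the scatter) and is the first single change that can be read in this set, as compound 1 and compound 2 differ in more than one place. On this aromatic carbon, para to a large group, dimethylamino leaves compound 3 not distinguishable from compound 2 on this read-out, so this one pair shows no difference larger than repeat measurements of this kind would produce. No measured evidence here bears on why the two compounds read alike.

This single pair cannot tell whether other groups at the same position, such as a carboxylic acid, a primary amine or the longer diethylamino, would also stay within the scatter of compound 2. It also leaves open whether dimethylamino would give a similar step on the core of compound 1, where other groups already sit on the aromatic rings.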